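Swapping 1,3-benzothiazol-2-yl for 2-fluorophenyl on an aromatic nitrogen

The source may report more compounds than this note shows. Statements on the series, on what has been measured and on what is new or still open speak of the compounds shown alone.

Compound 1 `COc1ccc(/C=C\C(=O)O)c(OCc2cn(-c3ccccc3C(=O)N3CCC(O)C3)nn2)c1CC=C(C)C` and compound 2 `COc1ccc(/C=C\C(=O)O)c(OCc2cn(-c3nc4ccccc4s3)nn2)c1CC=C(C)C` share a common core. In a functional assay on A-431 cells (Homo sapiens) for cytotoxicity, read by MTT assay, with a stated time of 24 h (on this read-out lower numbers stand for stronger inhibition and higher numbers for weaker inhibition), compound 1 gives 31500 nM, and compound 2 gives 20800 nM. Compound 2 holds the lowest of the two numbers, but its nearest neighbour, compound 1, lies within the scatter, so no order between them can be read. Compound 3 `COc1ccc(/C=C\C(=O)O)c(OCc2cn(-c3ccccc3F)nn2)c1CC=C(C)C` differs from compound 2 by 2-fluorophenyl in place of 1,3-benzothiazol-2-yl on an aromatic nitrogen. For the measured compounds named here, no step between measured compounds is available to guide this change, so the expected step is a 1.1-fold higher number from compound 2 to compound 3 (0.02 log units; within the scatter), within the scatter. Compound 3 is estimated at 22000 nM, with a range from 8000 nM to 60000 nM.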

Compound 3, half-maximal inhibitory concentration: 12400 nM
Compound 3: the middle estimate sits 1.8-fold (0.25 log units) above what was measured; the measured number falls inside the stated range.
By their numbers in this assay, from the lowest: compounds 3, 2 and 1 (each within the scatter of the next, the first and the last beyond it).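

In this assay, for the compounds shown here, the exchange of 1,3-benzothiazol-2-yl for 2-fluorophenyl on the aromatic nitrogen gives a 1.7-fold lower number from compound 2 to compound 3 (0.22 log units; within the scatter), so this position accepts a group without hydrogen-bond acceptors and with only one aromatic ring, with no readable difference. Fluoro in place of (3-hydroxypyrrolidin-1-yl)carbonyl on an aromatic carbon gives a 2.5-fold lower number from compound 1 to compound 3 (0.40 log units; beyond the scatter), the first modest difference beyond the scatter in this set. Nothing measured here accounts for that difference. As far as these compounds go, whether an amine or a methoxy group on that aromatic carbon would give a lower number remains open.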